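Chloro to methyl on an amide-type nitrogen's aryl group

The compounds below may be only part of what the source reports. "The series", "measured", "known", "first", "only" and "open" are said of these compounds alone.

Compound 1, `O=C(CN1CCN(c2cc3c(cc2F)c(=O)c(C(=O)O)cn3C2CC2)CC1)Nc1ccc(Cl)cc1`, carries a 4-chlorophenyl group on an amide-type nitrogen. In an ADME assay on WI-38 cells (Homo sapiens) for antiproliferative activity, read by BrdU incorporation, with a stated time of 24 h (a higher number here means a weaker inhibitor, a lower number a stronger inhibitor), compound 1 gives only a limit of the assay, > 100000 nM. Compound 2, `COc1ccccc1NC(=O)CN1CCN(c2cc3c(cc2F)c(=O)c(C(=O)O)cn3C2CC2)CC1`, carries 2-methoxyphenyl in place of 4-chlorophenyl on that nitrogen. In this assay compound 2 likewise gives only a limit, > 100000 nM. Compound 3, `COc1cc(NC(=O)CN2CCN(c3cc4c(cc3F)c(=O)c(C(=O)O)cn4C3CC3)CC2)cc(OC)c1OC`, carries 3,4,5-trimethoxyphenyl in the same position. Compound 3 also gives only a limit, > 100000 nM. For the measured compounds named here, every value so far therefore sits at the limit of > 100000 nM in this assay, at which 3 of the 3 values shown sit, and the three steps among them, a step that the two limits leave unreadable from compound 1 to compound 2, a step that the two limits leave unreadable from compound 1 to compound 3 and a step that the two limits leave unreadable from compound 2 to compound 3, cannot be sized.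

Compound 4, `Cc1ccc(NC(=O)CN2CCN(c3cc4c(cc3F)c(=O)c(C(=O)O)cn4C3CC3)CC2)cc1`, is the next candidate. It differs from compound 1 in a single change: methyl in place of chloro on an aromatic carbon. The three measured steps bear on this change only loosely: they show that exchanging the aryl group on the amide-type nitrogen among three different patterns never produced a number in this assay. No direction or size beyond the scatter can be read from them. Compound 4 is therefore expected to remain at the limit as well, with an estimated value of 150000 nM and a range from 50000 nM to 500000 nM. The step this estimate means, a step that the limit leaves unreadable from compound 1 to compound 4, is expected to be essentially none.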

Compound 4, half-maximal inhibitory concentration: > 100000 nM
Compound 4: a limit, no number (the forecaster's own chance of this, stated with the estimate: 85%); the middle value is on the limit's open side.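

Compound 4 gives only a limit in this assay, as do compound 1, compound 2 and compound 3, so no step from compound 4 to any of them can be read: the limit of > 100000 nM in this assay, at which 4 of the 4 values shown sit.

The compounds shown leave open whether any aryl group on the amide-type nitrogen of the shared core would give a readable number in this assay.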